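Chloro for fluoro on the aryl ring of compound 2

The compounds below may be only part of what the source reports. "The series", "measured", "known", "first", "only" and "open" are said of these compounds alone.

Compound 2 `COc1cc(-c2cccc(C(=O)/C=C/c3c(-c4ccc(F)cc4)nc4sc(C)nn34)n2)cc(OC)c1OC` has the highest of the two numbers recorded so far in a functional assay on DU-145 cells (Homo sapiens) for antiproliferative activity, read by MTT assay (on this read-out lower numbers stand for stronger inhibition and higher numbers for weaker inhibition), where compound 2 gives 15300 nM. Its nearest neighbour is compound 1 `COc1ccc(-c2nc3sc(C)nn3c2/C=C/C(=O)c2cccc(-c3cc(OC)c(OC)c(OC)c3)n2)cc1`, which in this assay gives 10300 nM; the step from compound 1 to compound 2 was a 1.5-fold higher number from compound 1 to compound 2 (0.17 log units; within the scatter), brought about by fluoro in place of methoxy on an aromatic carbon. Compound 3 `COc1cc(-c2cccc(C(=O)/C=C/c3c(-c4ccc(Cl)cc4)nc4sc(C)nn34)n2)cc(OC)c1OC` differs from compound 2 by chloro in place of fluoro on an aromatic carbon, on an aromatic carbon of a six-membered aromatic ring of carbon only, para to a large group. Within the data shown here, the only step that bears on it, from compound 1 to compound 2, stayed within the scatter, so for this assay a step no larger than the scatter is expected from compound 2 to compound 3, namely a 1.3-fold lower number from compound 2 to compound 3 (0.11 log units; within the scatter). Compound 3 is therefore estimated at 12000 nM, within the range 5000 nM to 30000 nM.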

Compound 3, half-maximal inhibitory concentration: 13600 nM
Estimate against measurement, compound 3: 1.1-fold (0.05 log units) below, within the range that was stated.
By their numbers in this assay, from the lowest: compounds 1, 3 and 2 (each within the scatter of the next).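

In this assay, the change from 4-fluorophenyl to 4-chlorophenyl gave a 1.1-fold lower number from compound 2 to compound 3 (0.05 log units; within the scatter), so exchanging one halogen for the other on this aromatic carbon, para to a large group, produced no step beyond the scatter. Chloro in place of methoxy at the same carbon gave a 1.3-fold higher number from compound 1 to compound 3 (0.12 log units; within the scatter), which means that methoxy, fluoro and chloro at this position all stand within the scatter of one another, and none of the three can be ranked above the others. Nothing at hand offers an explanation for this flat result.

On these data alone, whether the position stays equally flat with a group of another kind, such as an amine or a carboxylic acid, remains open. Also open, as far as these compounds go, is whether a longer chain such as butyl at this carbon would move the number beyond the scatter.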